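Aminomethylbenzyl for Phenyl: Expected Gain in Lung Half-Life

The source may report more compounds than this note shows. Statements on the series, on what has been measured and on what is new or still open speak of the compounds shown alone.

The series shares one core; compound 1 is `Cc1csc2cc([C@H](C)Nc3ncnc(N)c3C#N)c(-c3cccc(CN(C)CCCCN(C)Cc4ccccc4)c3)c(=O)n12` and compound 2 is `Cc1csc2cc([C@H](C)Nc3ncnc(N)c3C#N)c(-c3cccc(CN4CCC(N(C)CC(C)C)CC4)c3)c(=O)n12`. In an ADME assay on the whole organism (lung, Rattus norvegicus) for metabolic stability, read by LC-MS (a higher number here means that the compound lasts longer, a lower number that the compound disappears faster), compound 1 gives 17.6 h, and compound 2 gives 9.9 h. Compound 3, `Cc1csc2cc([C@H](C)Nc3ncnc(N)c3C#N)c(-c3ccccc3)c(=O)n12`, carries only a phenyl at the corresponding aromatic carbon. In this assay compound 3 gives only a limit, < 0.1 h, so its true half-life is not known as a number. Of the three values shown, one sits at the limit of < 0.1 h in this assay, at which 1 of the 3 values shown sits, and that one belongs to compound 3.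

Compound 4 is `Cc1csc2cc([C@H](C)Nc3ncnc(N)c3C#N)c(Cc3cccc(CN)c3)c(=O)n12`. The change from compound 3 to compound 4 is 3-(aminomethyl)benzyl in place of phenyl on an aromatic carbon. Going by the values given here, no step between measured compounds is available for this change, so only the values of compounds 1, 2 and 3 guide the expectation. Compounds 1 and 2 both bear an amine-containing substituent on the corresponding ring. In this assay compound 1 gives 17.6 h and compound 2 gives 9.9 h, both far above where compound 3 sits. The step from compound 3 to compound 4 in this assay is therefore expected to be upward and well beyond the scatter, about an at least 30-fold higher number from compound 3 to compound 4 (1.47 log units; beyond the scatter). Compound 4 is estimated at 3 h, with a range from 0.5 h to 15 h.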

Compound 4, half-life: 1.6 h
The estimate for compound 4 lay 1.9-fold (0.27 log units) above the measured number; the measured number falls inside the stated range.
By their numbers in this assay, from the lowest: compound 4; then compounds 2 and 1 (each within the scatter of the next). At a limit, below all of these: compound 3.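

In this assay, this aromatic carbon now has its first readable step, with 3-(aminomethyl)benzyl in place of phenyl: an at least 16-fold higher number from compound 3 to compound 4 (1.20 log units; beyond the scatter). The change is large and lies beyond the scatter, but its size is only a lower bound. Compound 3 stands at a limit, not a number: the limit of < 0.1 h in this assay, at which 1 of the 4 values shown sits.

The change alters two things at once, adding a carbon link to the shared core and an aminomethyl group on the ring, and the compounds shown do not separate these two parts. Plain benzyl and 3-(aminomethyl)phenyl would each carry only one part, while a carboxylic acid or a hydroxymethyl group in place of the aminomethyl would leave open whether the nitrogen is needed for the gain in this assay.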